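A few compounds are considered here, and "the series" means these few. Any claim that something is new, unique, unknown or untested is made for them only; others in the source may bear on it.

Two compounds carry measurements so far. Compound 1 `N=C(N)c1ccc(-c2ccc(-c3cc(Cl)cc(Cl)c3)s2)s1` in a functional assay on HCT-116 cells (Homo sapiens) for inhibition, read by sulforhodamine B assay, with a stated time of 48 h (on this read-out lower numbers stand for stronger inhibition of growth and higher numbers for weaker inhibition of growth), gives 1610 nM. Compound 2 `COc1ccc(-c2ccc(-c3ccc(C(=N)N)o3)o2)cc1` in this assay gives 1070 nM, the lower of the two numbers, though its gap to compound 1 lies within the scatter. Compound 3 `N=C(N)c1ccc(-c2ccc(-c3ccc(Cl)cc3)o2)o1` has not yet been measured; it differs from compound 2 by chloro in place of methoxy on an aromatic carbon. Among the compounds with values here, no step between measured compounds shows the effect of this change, so in this assay no shift beyond the scatter is expected. Compound 3 is therefore estimated at 1200 nM, within 500 nM to 3000 nM, which amounts to an expected step of a 1.1-fold higher number from compound 2 to compound 3 (0.05 log units; within the scatter).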

Compound 3, concentration for 50% growth inhibition: 1900 nM
For compound 3 the middle estimate is 1.6-fold (0.20 log units) below the measured one; measured number inside the range.
By their numbers in this assay, from the lowest: compounds 2, 1 and 3 (each within the scatter of the next).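

In this assay the change of chloro in place of methoxy on an aromatic carbon, para to a large group, gives a 1.8-fold higher number from compound 2 to compound 3 (0.25 log units; within the scatter) and so provides the first step read at this position. The step lies within the scatter, so these two groups cannot be told apart here by growth inhibition. No evidence bears on this result.

The compounds shown leave open whether an amine or a carboxylic acid at this place would move the number beyond the scatter. They also leave open whether a longer chain such as butoxy would do so.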